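From methoxy to pyridin-2-yl on the shared core

The compounds below may be only part of what the source reports. "The series", "measured", "known", "first", "only" and "open" are said of these compounds alone.

Compound 1 `COc1ccc2c(c1)CN(C(=O)c1cc(S(C)(=O)=O)ccc1O[C@@H](C)C(F)(F)F)C2` gives 46 ug/mL
Compound 2 `C[C@H](Oc1ccc(S(C)(=O)=O)cc1C(=O)N1Cc2cnc(C(F)(F)F)cc2C1)C(F)(F)F` gives 470 ug/mL

In a physicochemical assay for solubility (a higher number here means a more soluble compound, a lower number a less soluble compound), compound 1 holds the lower of the two numbers, and compound 2 stands well above it, beyond the usual scatter. Compound 3 `C[C@H](Oc1ccc(S(C)(=O)=O)cc1C(=O)N1Cc2ccc(-c3ccccn3)cc2C1)C(F)(F)F` carries pyridin-2-yl in place of the methoxy of compound 1, on an aromatic carbon (pyridin-2-yl in place of methoxy on an aromatic carbon). For the measured compounds named here, no measured pair shows this change on its own, so the expectation is uncertain. In this assay the expected step is a small fall a 1.8-fold lower number from compound 1 to compound 3 (0.26 log units; within the scatter) that may stay within the scatter. The estimated value for compound 3 is 25 ug/mL, within a range of 7 ug/mL to 90 ug/mL.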

Compound 3, solubility: 30 ug/mL
The estimate for compound 3 lay 1.2-fold (0.08 log units) below the measured number, and the stated range covers the measured number.
By their numbers in this assay, from the lowest: compounds 3 and 1 (each within the scatter of the next); then compound 2.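

In this assay, putting pyridin-2-yl in place of methoxy on this aromatic carbon gives a 1.5-fold lower number from compound 1 to compound 3 (0.19 log units; within the scatter) for a swap that adds a whole six-membered aromatic ring. At this position, then, a group of 6 heavy atoms and one of 2 heavy atoms give numbers that cannot be told apart. Nothing measured here explains this closeness. The compounds shown leave open whether an amine or a carboxylic acid on this same carbon would shift the number beyond the scatter. As far as these compounds go, whether pyridin-3-yl would match pyridin-2-yl also remains open.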